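Swapping propyl for benzyl on an inactive core

This account rests on a few compounds, and the source may have more. Where it says the series, first, only, none or still open, it means among the compounds named here.

- compound 1 `CCC[C@@H]1O[C@H](COCc2ccccc2)[C@@H](OCc2ccccc2)[C@H](OCc2ccccc2)C1=O`: > 50000 nM
- compound 2 `CCC[C@H]1O[C@H](COCc2ccccc2)[C@@H](OCc2ccccc2)[C@H](OCc2ccccc2)C1=O`: > 50000 nM

In a functional assay on HOS cells (Homo sapiens) for antiproliferative activity, read by sulforhodamine B assay (on this read-out lower numbers stand for stronger inhibition of growth and higher numbers for weaker inhibition of growth), compound 1 gives > 50000 nM, which is a limit and not a number. Compound 2 gives > 50000 nM, again only a limit. Both therefore stand at the limit of > 50000 nM in this assay, at which 2 of the 2 values shown sit. Within the data shown here, the only measured step, a step that the two limits leave unreadable from compound 1 to compound 2, concerns (the fact that compounds 1 and 2 differ only in the configuration as drawn), so it offers no size to carry over.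

Compound 3 `O=C1[C@H](Cc2ccccc2)O[C@H](COCc2ccccc2)[C@@H](OCc2ccccc2)[C@@H]1OCc1ccccc1` brings a different kind of change: phenyl in place of ethyl on a saturated chain carbon bound to a saturated ring carbon, or propyl to benzyl. With no measured size to draw on, the expectation rests on compound 1 at > 50000 nM, a limit. Growth inhibition in this assay is expected to stay weak, and another limit is the likeliest report. The expected step is a number no higher from compound 1 to compound 3 (the limit leaves the size open), with any gain in strength small. The estimate for compound 3 is 50000 nM, with an expected range from 15000 nM to 100000 nM.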

Compound 3, concentration for 50% growth inhibition: > 50000 nM
Compound 3: a limit, no number; the forecaster's own chance of this, stated with the estimate: 70%; the middle value lies on the limit itself.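

In this assay compound 3 gives > 50000 nM, which is a limit and not a number. Set against compound 1, it therefore yields no step that can be read. The compounds shown leave open whether any change on the shared core brings growth inhibition that can be given as a number.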